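Notes on the chloro-to-hydrogen step across two sub-series

The source may report more compounds than this note shows. Statements on the series, on what has been measured and on what is new or still open speak of the compounds shown alone.

Compound 1 `NC(=O)c1c(NC(=O)c2ccccc2Cl)sc2c1CCN(Cc1ccc(Cl)cc1)C2` and compound 2 `NC(=O)c1c(NC(=O)c2ccccc2Cl)sc2c1CCN(Cc1ccc(Cl)cc1Cl)C2` share one core; compound 3 `NC(=O)c1c(NC(=O)c2ccccc2)sc2c1CCN(C(=S)Nc1ccccc1Cl)C2` and compound 4 `NC(=O)c1c(NC(=O)c2ccccc2)sc2c1CCN(C(=S)Nc1ccccc1)C2` share another, and the difference between the two cores is not broken down here. In a functional assay on HL-60 cells (Homo sapiens) for antiproliferative activity, with a stated time of 24 h (a higher number here means a weaker inhibitor, a lower number a stronger inhibitor), compound 2 gives 8010 nM and compound 1 gives 22500 nM, so a 2.8-fold higher number from compound 2 to compound 1 (0.45 log units; beyond the scatter); the change is hydrogen in place of chloro on an aromatic carbon. In this assay compound 3 gives 13800 nM. The change to compound 4 is hydrogen in place of chloro on an aromatic carbon; its place is ortho to a large group but, unlike the first case, not meta to a chloro group, so it is the same kind of change, not the same. For the measured compounds named here, a step like a 2.2-fold higher number from compound 3 to compound 4 (0.34 log units; beyond the scatter) is expected, resting on a 2.8-fold higher number from compound 2 to compound 1 (0.45 log units; beyond the scatter) as the single precedent. Compound 4 is estimated at 30000 nM, between 12000 nM and 75000 nM.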

Compound 4, half-maximal inhibitory concentration: > 50000 nM
Compound 4 gave a limit, no number; the forecaster's own chance of this, stated with the estimate: 15%; middle value at least 1.6-fold (0.22 log units) from the limit.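

In this assay compound 4 gives > 50000 nM, which is a limit of the assay and not a number. Hydrogen in place of chloro gives an at least 3.6-fold higher number from compound 3 to compound 4 (0.55 log units; beyond the scatter), the same direction as on the core of compound 1, so in these two pairs the direction of the change carries from one core to the other: the same change on two cores in this assay, a 2.8-fold higher number (0.45 log units; beyond the scatter) from compound 2 to compound 1 and an at least 3.6-fold higher number (0.55 log units; beyond the scatter) from compound 3 to compound 4; the limit leaves it open whether they differ Whether the size of the step also carries over is not shown, as the step on the core of compound 3 has no upper end: the limit of > 50000 nM in this assay, at which 1 of the 4 values shown sits.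

Open, as far as these compounds go, is whether fluoro, methoxy or an amine in place of the chloro would move the number the same way on either core. Two pairs also leave open whether the change would carry to a third core.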